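A few compounds are considered here, and "the series" means these few. Any claim that something is new, unique, unknown or untested is made for them only; others in the source may bear on it.

Measured so far in a functional assay on HCT-116 cells (Homo sapiens) for inhibition, read by MTT assay, with a stated time of 48 h; on this read-out lower numbers stand for stronger inhibition and higher numbers for weaker inhibition:

Compound 1, `Cc1nnsc1CO/N=C/c1c(C)nn(C)c1Oc1ccc(OC(F)(F)F)cc1`, gives 12800 nM.
Compound 2, `CCc1nnsc1CO/N=C/c1c(C)nn(C)c1Oc1ccccc1Cl`, gives 17600 nM.
Compound 3, `CCc1nnsc1CO/N=C/c1c(C)nn(C)c1Oc1ccc(OC(F)(F)F)cc1`, gives 12500 nM.

Compound 1 and compound 3 share a core and differ in one spot: methyl in place of hydrogen on a saturated chain carbon bound to an aromatic carbon. That single change gave a 1.0-fold lower number from compound 1 to compound 3 (0.01 log units; within the scatter), so on this read-out the two compounds cannot be told apart. Compound 2 carries a different core; how it differs from the core of compound 1 is not broken down here. Its number and those of compound 1 and compound 3 all lie close together.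

Compound 4, `CCCc1nnsc1CO/N=C/c1c(C)nn(C)c1Oc1ccccc1Cl`, has not yet been measured in this assay. It differs from compound 2 by methyl in place of hydrogen on a saturated chain carbon, two bonds along the chain from an aromatic carbon. This is the same kind of change as from compound 1 to compound 3 but not the same one: there the entering group sits on a saturated chain carbon bound to an aromatic carbon, here on a saturated chain carbon two bonds along the chain from an aromatic carbon. The expected step from compound 2 to compound 4 is a 1.1-fold lower number from compound 2 to compound 4 (0.04 log units; within the scatter), because a 1.0-fold lower number from compound 1 to compound 3 (0.01 log units; within the scatter) showed the earlier change of this kind left the number essentially unmoved. Compound 4 is therefore expected to give about 16000 nM, estimated between 7000 nM and 36000 nM.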

Compound 4, half-maximal inhibitory concentration: 16400 nM
Beside the measured number, compound 4's estimate is 1.0-fold (0.01 log units) below it; measured number inside the range.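

Lengthening the chain from ethyl to propyl gave a 1.1-fold lower number from compound 2 to compound 4 (0.03 log units; within the scatter), so in this assay this change leaves the number as unmoved on the core of compound 2 as methyl to ethyl did on the core of compound 1. Set side by side, the two steps do not differ: the same change on two cores in this assay, a 1.0-fold lower number (0.01 log units; within the scatter) from compound 1 to compound 3 and a 1.1-fold lower number (0.03 log units; within the scatter) from compound 2 to compound 4, 1.0-fold (0.02 log units) apart, within the scatter of two such steps. This shows only that one added methyl on this chain made no readable difference on two cores; the two steps start from different chains, and since neither moved the number, they cannot show whether a step of real size would carry from one core to the other.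

The compounds shown leave open whether a longer chain such as butyl, or a branched one such as isopropyl, would also leave the number unmoved. They also leave open whether an amine or a carboxylic acid in place of that chain would move the number at all.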